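Adding a cyano group to the phenoxy ring of compound 1

This account rests on a few compounds, and the source may have more. Where it says the series, first, only, none or still open, it means among the compounds named here.

Compound 1 `CCS(=O)(=O)Nc1ccc(Oc2ccccc2)c(-c2cn(C)c(=O)c3[nH]ccc23)c1` is the more potent of the two measured compounds: in a functional assay on MX1 cells (Homo sapiens) for antiproliferative activity, with a stated time of 72 h (on this read-out higher numbers stand for an effect only at larger amounts of compound and lower numbers for an effect already at smaller amounts), compound 1 gives 14 nM. Its companion compound 2 `Cn1cc(-c2cc(C(N)=O)ccc2Oc2ccccc2)c2cc[nH]c2c1=O` gives 120 nM in this assay. For the measured compounds named here, the one measured step, an 8.6-fold higher number from compound 1 to compound 2 (0.93 log units; beyond the scatter), swaps the (ethylsulfonyl)amino group for a carbamoyl group and leaves the phenoxy ring untouched. Compound 3 `CCS(=O)(=O)Nc1ccc(Oc2ccc(C#N)cc2)c(-c2cn(C)c(=O)c3[nH]ccc23)c1` keeps the (ethylsulfonyl)amino group and instead alters the phenoxy ring: cyano in place of hydrogen on an aromatic carbon, on an aromatic carbon of a six-membered aromatic ring of carbon only, para to a large group. Going by the values given here, no measured step touches this ring, so the step from compound 1 to compound 2 gives no direct guide to what a cyano group there will do. With nothing pointing either way, compound 3 is expected to sit near its parent, a step of a 1.1-fold higher number from compound 1 to compound 3 (0.03 log units; within the scatter) that stays within the scatter. The estimate for compound 3 is 15 nM, within a range of 5 nM to 45 nM.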

Compound 3, half-maximal effective concentration: 17 nM
The estimate for compound 3 lay 1.1-fold (0.05 log units) below the measured number; measured number inside the range.
By their numbers in this assay, from the lowest: compounds 1 and 3 (each within the scatter of the next); then compound 2.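

Adding a cyano group to the phenoxy ring, on the aromatic carbon para to a large group, gives a 1.2-fold higher number from compound 1 to compound 3 (0.08 log units; within the scatter) in this assay, so in this one case the two added heavy atoms leave the number unchanged within the scatter. For the compounds shown here, this is the first measured change on this ring, and it contrasts with the change at the (ethylsulfonyl)amino group, an 8.6-fold higher number from compound 1 to compound 2 (0.93 log units; beyond the scatter), which lies beyond the scatter. There is no measurement here that could explain why the number holds.

Still open, as far as these compounds go, is whether other groups on this carbon, such as an amine or a carboxylic acid, would also leave the number in place, and whether a cyano group on another carbon of the ring would do the same. From the compounds shown here alone, it is also open whether the cyano group would have as little effect on compound 2, which carries the carbamoyl group.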